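The source may hold more compounds than are shown below. What is called first, only, known or untested is meant among the compounds shown, and "the series" means these compounds.

Measured compounds:
- compound 1 `CC(C)(C)c1ccc(C(=O)NN2C(=O)NC3(CC3(C)C)C2=O)cc1`: in a functional assay on the whole organism (Hindlimb) for inhibition, with Mus musculus as the target, with a stated time of 4 h (a lower number here means that less compound is needed, a higher number that more compound is needed for the effect), compound 1 gives 100 mg/kg
- compound 2 `CC1(C)CC12NC(=O)N(NC(=O)c1ccc(Br)cc1)C2=O`: compound 2 gives 300 mg/kg
- compound 3 `CC1(C)CC12NC(=O)N(NC(=O)c1ccc(F)cc1)C2=O`: compound 3 gives 300 mg/kg

Compound 3 stands level with compound 2, and the two together carry the highest numbers of the three. Its furthest neighbour is compound 1, from which the step was a 3.0-fold higher number from compound 1 to compound 3 (0.48 log units; beyond the scatter); from compound 2 the step was no change at the digits printed from compound 2 to compound 3 (within the scatter).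

Compound 4 `CC1(C)CC12NC(=O)N(NC(=O)c1cccs1)C2=O` differs from compound 3 in one place: thiophen-2-yl in place of 4-fluorophenyl on a carbonyl carbon. For the measured compounds named here, none of the measured steps changes the aromatic ring itself. Two steps, a 3.0-fold higher number from compound 1 to compound 2 (0.48 log units; beyond the scatter) and a 3.0-fold higher number from compound 1 to compound 3 (0.48 log units; beyond the scatter), concern only a substituent on that ring, and the halogen swap no change at the digits printed from compound 2 to compound 3 (within the scatter) stayed within the scatter. The data therefore give no direct guide to replacing the ring, and no step beyond the scatter is expected in this assay; the step from compound 3 to compound 4 is estimated as no change at the digits printed from compound 3 to compound 4 (within the scatter). Compound 4 is expected to give about 300 mg/kg, within a range from 100 mg/kg to 1000 mg/kg.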

Compound 4, minimum effective dose: 300 mg/kg
Estimate against measurement, compound 4: no gap at the digits printed, and the stated range covers the measured number.
By their numbers in this assay, from the lowest: compound 1; then compounds 2, 3 and 4 (each within the scatter of the next).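

In this assay, thiophen-2-yl in place of 4-fluorophenyl on the carbonyl carbon gave no change at the digits printed from compound 3 to compound 4 (within the scatter), and thiophen-2-yl in place of 4-bromophenyl gave no change at the digits printed from compound 2 to compound 4 (within the scatter). The earlier compounds shown here varied only a substituent on a six-membered aromatic ring of carbon only, whereas these steps show that the ring itself can be exchanged at this position for a five-membered aromatic ring with one hetero atom, with fewer heavy atoms, and the number stays level with those of both halogen compounds. No measurement at hand explains this result.

As far as these compounds go, whether a tert-butyl group on the thiophen-2-yl ring would move the number as it does on the phenyl ring remains open. Also open, from the compounds shown here alone, is how a pyridine ring, a saturated cyclohexyl ring or an amine-bearing ring would read on this carbonyl carbon.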